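The source may hold more compounds than are shown below. What is called first, only, known or untested is meant among the compounds shown, and "the series" means these compounds.

Working notes on the series in a functional assay on HepG2 cells (Homo sapiens) for inhibition, read by MTT assay, with a stated time of 48 h; a lower number here means a stronger inhibitor, a higher number a weaker inhibitor.

Compound 1 `CCOC(=O)C1=C(N/C=N/c2cccnc2Cl)Nc2[nH]nc(C)c2C1c1ccc(N(C)C)cc1` carries a chloropyridinyl formamidine on the amine nitrogen of the shared core; in this assay compound 1 gives 4890 nM. Compound 2 `CCOC(=O)C1=C(N/N=C(\c2ccc([N+](=O)[O-])cc2)N2CCN(c3ccc(F)cc3)CC2)Nc2[nH]nc(C)c2C1c1ccc(N(C)C)cc1` carries a much larger hydrazone on the same nitrogen; in this assay compound 2 gives 90200 nM. Compound 3 `CCOC(=O)C1=C(N/N=C(\C#N)C(N)=O)Nc2[nH]nc(C)c2C1c1ccc(N(C)C)cc1` carries the cyano-amide hydrazone; in this assay compound 3 gives 48400 nM.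

Compound 3 stands second highest of the three numbers: its nearest neighbour is compound 2, within the scatter, and its furthest is compound 1, beyond the scatter. For the measured compounds named here, the one single-point step so far, a 9.9-fold higher number from compound 1 to compound 3 (1.00 log units; beyond the scatter), shows that the chain on the amine nitrogen weakened inhibition relative to the chloropyridinyl group.

Compound 4 `CCOC(=O)C1=C(N)Nc2[nH]nc(C)c2C1c1ccc(N(C)C)cc1` removes that chain altogether: a hydrogen atom in place of a group of 7 heavy atoms (3 carbon, 3 nitrogen, 1 oxygen; no ring), on an amine nitrogen. Going by the values given here, no measured step bears directly on stripping the amine nitrogen bare, and the step from compound 1 to compound 3 gives no direction for a further reduction. The working expectation is therefore a step of a 1.2-fold lower number from compound 3 to compound 4 (0.08 log units; within the scatter), essentially none beyond the scatter, with wide uncertainty. Compound 4 is estimated at 40000 nM, within a range from 10000 nM to 160000 nM.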

Compound 4, half-maximal inhibitory concentration: 4240 nM
Compound 4: middle estimate off by 9.4-fold (0.97 log units), on the high side; measured number outside the range, below it.
By their numbers in this assay, from the lowest: compounds 4 and 1 (each within the scatter of the next); then compounds 3 and 2 (each within the scatter of the next).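

In this assay, the cyano-amide hydrazone chain is shown to be a liability on this amine nitrogen rather than part of what the series needs: replacing it with a hydrogen atom gives an 11-fold lower number from compound 3 to compound 4 (1.06 log units; beyond the scatter). The chloropyridinyl formamidine group, by contrast, can be removed with no change beyond the scatter, a 1.2-fold lower number from compound 1 to compound 4 (0.06 log units; within the scatter), so the bare amine nitrogen and this ring-bearing group are on a level and the group adds nothing measurable to inhibition here. No measurement available bears on why these changes have these outcomes.

Compound 4 gives 4240 nM, and the compounds shown leave open whether any group on this nitrogen can bring the number clearly further down, since the substituents compared so far only match it or lose to it. A small acyl group such as acetyl, a short alkyl chain such as methyl or ethyl, or a pyridine ring without the chlorine would show whether the loss belongs to the hydrazone chain in particular or to substitution on this nitrogen more generally.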